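Cytotoxicity notes on the shared core: compound 4

The compounds below may be only part of what the source reports. "The series", "measured", "known", "first", "only" and "open" are said of these compounds alone.

Compound 1 `CCOC(=O)c1c(-c2cc(F)cc(OC)c2)[nH]c2cc(OC)ccc2c1=O` was tested in an ADME assay on BJ cells (Homo sapiens) for cytotoxicity, read by luminescence, with a stated time of 72 h; on this read-out higher numbers stand for an effect only at larger amounts of compound and lower numbers for an effect already at smaller amounts. In this assay compound 1 gives only a limit, > 21500 nM. Compound 2 `CCOC(=O)c1c(-c2cccc(C(F)(F)F)c2)[nH]c2cc(OC)ccc2c1=O` carries a trifluoromethyl group in place of the fluorine and methoxy; in this assay compound 2 also gives only a limit, > 21500 nM. Compound 3 `CCOC(=O)c1c(-c2cccc([N+](=O)[O-])c2)[nH]c2cc(OC)ccc2c1=O` carries a nitro group; in this assay compound 3 likewise gives only a limit, > 21500 nM. Compound 1 thus stands at the same point as the other two, namely (the limit of > 21500 nM in this assay, at which 3 of the 3 values shown sit), and no ordering among compounds 1, 2 and 3 can be read from these numbers.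

Compound 4 `CCOC(=O)c1c(-c2cccc(CO)c2)[nH]c2cc(OC)ccc2c1=O` has not yet been measured in this assay. It differs from compound 1 as follows: 3-(hydroxymethyl)phenyl in place of 3-fluoro-5-methoxyphenyl on an aromatic carbon. The measured steps that bear on this position are a step that the two limits leave unreadable from compound 1 to compound 3 and a step that the two limits leave unreadable from compound 2 to compound 3; both are unreadable, each end sitting at the limit. No change of the aryl group at this aromatic carbon has so far moved the read-out off the limit, so no step beyond the scatter is expected for the hydroxymethyl change either.

The step from compound 1 to compound 4 is therefore expected to be a step that the limit leaves unreadable from compound 1 to compound 4, in effect none. Compound 4 is estimated at 25000 nM, in the range 15000 nM to 60000 nM, with the result most likely reported again as a limit.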

Compound 4, half-maximal effective concentration: > 21500 nM
Compound 4: only a limit was reported (the forecaster's own chance of this, stated with the estimate: 85%); the middle value does not contradict the limit.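

In this assay the steps between compound 4 and compounds 1, 2 and 3 cannot be read, since each end is a limit and not a number: the limit of > 21500 nM in this assay, at which 4 of the 4 values shown sit.

The compounds shown leave open whether any aryl group at this aromatic carbon of the shared core brings the read-out off the limit, and how far compounds 1, 2, 3 and 4 lie from one another.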